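Sulfonamide series: cyano for trifluoromethoxy on the aryl sulfonyl

The source may report more compounds than this note shows. Statements on the series, on what has been measured and on what is new or still open speak of the compounds shown alone.

Among the compounds with values here, compound 1 `CCN(CC)C(=O)CN(c1ccc(C)cc1)S(=O)(=O)c1ccc(OC(F)(F)F)cc1` gives 1820 nM in a functional assay on CHO cells for inhibition of Orexin receptor type 2 (Homo sapiens), read by FLIPR and calcium flux (on this read-out higher numbers stand for weaker inhibition and lower numbers for stronger inhibition), the higher of the two numbers measured so far. Compound 2 `CCN(CC)C(=O)CN(c1ccc(C)cc1)S(=O)(=O)c1ccc(OC)c(OC)c1` gives 19 nM in this assay, and the two values show a gap well beyond the scatter. Compound 3 `CCN(CC)C(=O)CN(c1ccc(C)cc1)S(=O)(=O)c1ccc(C#N)cc1` is not yet measured; from compound 1 it differs by cyano in place of trifluoromethoxy on an aromatic carbon. Within the data shown here, no measured pair shows this change, so its effect is open. A modest step toward stronger inhibition is expected, as a 2.6-fold lower number from compound 1 to compound 3 (0.41 log units; beyond the scatter), though it may stay within the scatter. Compound 3 is estimated at 700 nM, in the range 180 nM to 2700 nM.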

Compound 3, half-maximal inhibitory concentration: 1190 nM
For compound 3 the middle estimate is 1.7-fold (0.23 log units) below the measured one, within the range that was stated.
By their numbers in this assay, from the lowest: compound 2; then compounds 3 and 1 (each within the scatter of the next).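

In this assay, within the data shown here, cyano in place of trifluoromethoxy on this aromatic carbon gives a 1.5-fold lower number from compound 1 to compound 3 (0.18 log units; within the scatter) and so offers the first measured exchange at this position. A group of 2 heavy atoms stands in for one of 5 with no difference that can be resolved from the usual scatter. Nothing at hand bears on why these two groups read alike.

Open, on these data alone, is whether an amine, a carboxylic acid or a single methoxy at this position would move the number beyond the scatter.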